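The source may hold more compounds than are shown below. What is called first, only, known or untested is meant among the compounds shown, and "the series" means these compounds.

Measured so far:
Compound 1 `CN(C)[C@H]1CCN(c2cccc3c2C[C@H](CN(C)[C@H]2CCCc4cccnc42)NC3)C1`: 67.5%
Compound 2 `CN(C)C1CCN(c2cccc3c2C[C@H](CN(C)[C@H]2CCCc4cccnc42)NC3)CC1`: 78.4%

For the measured compounds named here, in an ADME assay on microsomes from liver (Homo sapiens) for metabolic stability, using NADPH, with a stated time of 10 min (on this read-out higher numbers stand for a more stable compound and lower numbers for a less stable compound), compound 2 holds the higher of the two numbers, at 78.4%, and compound 1 is the only neighbour, at 67.5%. The next compound to be read is compound 3 `CN(C[C@H]1Cc2c(cccc2N2C[C@H]3CCN(C)[C@H]3C2)CN1)[C@H]1CCCc2cccnc21`, and the change is a group of 9 heavy atoms (7 carbon, 2 nitrogen; 2 five-membered non-aromatic rings with 1 hetero atom each) in place of a group of 9 heavy atoms (7 carbon, 2 nitrogen; one six-membered non-aromatic ring with 1 hetero atom), on an aromatic carbon. Going by the values given here, the swap falls on the same aromatic carbon as the only measured step, a number 10.9 percentage points higher from compound 1 to compound 2 (beyond the scatter), which is modest and beyond the scatter. In that step, 4-(dimethylamino)piperidin-1-yl took the place of 3-(dimethylamino)pyrrolidin-1-yl. Among the compounds with values here, the entering group of compound 3 has no common name, carries 2 defined stereocentres and has no measured counterpart, so a single step is thin support. Its five-membered rings give some resemblance to the group of compound 1, which reads 67.5%. A modest fall of about the same size as the measured step is therefore expected, in the opposite direction: a number 11.4 percentage points lower from compound 2 to compound 3 (beyond the scatter). The estimate for compound 3 is 67%, with an expected range of 50% to 82%.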

Compound 3, percent of the compound remaining: 97.6%
Beside the measured number, compound 3's estimate is 30.6 percentage points below it; the measured number lies above the stated range.
By their numbers in this assay, from the lowest: compound 1; then compound 2; then compound 3.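

In this assay, the aromatic carbon ortho to a fused ring still has room for change once 4-(dimethylamino)piperidin-1-yl is in place: the fused group with 2 five-membered non-aromatic rings gives a number 19.2 percentage points higher from compound 2 to compound 3 (beyond the scatter), and the comparison with the smaller 3-(dimethylamino)pyrrolidin-1-yl gives a number 30.1 percentage points higher from compound 1 to compound 3 (beyond the scatter). Five-membered rings therefore do not go with the lower number across this set: compound 1 fits that reading, while compound 3 goes against it and holds the highest number of the three, beyond the scatter from both others. The counts do not separate compound 2 from compound 3, which share 9 heavy atoms, 2 nitrogen atoms, 0 hydrogen-bond donors and 2 hydrogen-bond acceptors, and nothing available accounts for the difference between them.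

The compounds shown leave open whether a morpholin-4-yl group, a piperazin-1-yl group or an open-chain amine on this aromatic carbon would stay near compound 3 in this assay. They also leave open how much of the result depends on the 2 defined stereocentres of the entering group, since its other stereoisomers are not among them.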